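Methyl at the six-membered ring carbon: compound 4

The compounds below may be only part of what the source reports. "The series", "measured", "known", "first", "only" and "open" are said of these compounds alone.

In a functional assay for antagonist activity at P2Y purinoceptor 1 (Homo sapiens) (on this read-out higher numbers stand for weaker inhibition and lower numbers for stronger inhibition), compound 3 `CNc1ncnc2c1ncn2[C@H]1C[C@H](OP(=O)(O)O)[C@]2(COP(=O)(O)O)C[C@H]12` gives 157 nM and stands second highest of the three measured numbers; compound 1 `CNc1nc(Cl)nc2c1ncn2[C@H]1C[C@H](OP(=O)(O)O)[C@]2(COP(=O)(O)O)C[C@H]12` gives 52 nM and compound 2 `CSc1nc(N)c2ncn([C@H]3C[C@H](OP(=O)(O)O)[C@]4(COP(=O)(O)O)C[C@H]34)c2n1` gives 367 nM. For the measured compounds named here, the one single-site step known, a 3.0-fold higher number from compound 1 to compound 3 (0.48 log units; beyond the scatter), shows that a substituent at this carbon lowers the number beyond the scatter. Compound 4 `CNc1nc(C)nc2c1ncn2[C@H]1C[C@H](OP(=O)(O)O)[C@]2(COP(=O)(O)O)C[C@H]12` differs from compound 3 by methyl in place of hydrogen on an aromatic carbon. The chloro step bears directly on this position; methyl is a substituent of like size, so a lower number than compound 3 is expected for compound 4, of modest size, a 2.0-fold lower number from compound 3 to compound 4 (0.29 log units; within the scatter). The estimate for compound 4 is 80 nM, with a range of 35 nM to 180 nM.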

Compound 4, half-maximal inhibitory concentration: 49 nM
For compound 4 the middle estimate is 1.6-fold (0.21 log units) above the measured one; measured number inside the range.
By their numbers in this assay, from the lowest: compounds 4 and 1 (each within the scatter of the next); then compound 3; then compound 2.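

Methyl on the aromatic carbon between two ring nitrogen atoms clearly moves the number from the hydrogen compound (a 3.2-fold lower number from compound 3 to compound 4 (0.51 log units; beyond the scatter)), so the effect of a substituent here is not confined to chloro. Methyl and chloro cannot be told apart at this carbon (a 1.1-fold lower number from compound 1 to compound 4 (0.03 log units; within the scatter)). No measurement at hand explains this result. Going by these compounds, whether an amine, a methoxy group or a longer chain such as propyl at this carbon would match methyl and chloro remains open. So does whether methyl gives the same result with other groups in place of methylamino.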